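A few compounds are considered here, and "the series" means these few. Any claim that something is new, unique, unknown or untested is made for them only; others in the source may bear on it.

In an ADME assay on PC-3 cells (Homo sapiens) for cytotoxicity, read by WST assay, tested at 100 uM (on this read-out lower numbers stand for less inhibition and higher numbers for more inhibition at the one concentration tested (going by the name of the read-out)), three compounds have been measured so far:

Compound 1 `Cc1cccc(C(=O)N2CCCC(C(=O)Nc3ccc(Cl)cc3)C2)c1` gives 0%.
Compound 2 `O=C(Nc1ccc(Cl)cc1)C1CCCN(C(=O)c2cccc(-c3cccs3)c2)C1` gives 4%.
Compound 3 `O=C(Nc1ccc(Cl)cc1)C1CCCN(C(=O)c2cccc(-c3cnco3)c2)C1` gives 0%.

Compound 3 stands level with compound 1 at the digits shown, and the remaining step among the three is a number 4 percentage points lower from compound 2 to compound 3 (within the scatter). All three numbers sit near the bottom of the scale, and every step among them lies within the scatter: a number 4 percentage points higher from compound 1 to compound 2 (within the scatter) and no change at the digits printed from compound 1 to compound 3 (within the scatter). Compound 4 `Cc1nc(-c2cccc(C(=O)N3CCCC(C(=O)Nc4ccc(Cl)cc4)C3)c2)cs1` is the next compound to be tested. The change from compound 3 is 2-methyl-1,3-thiazol-4-yl in place of 1,3-oxazol-5-yl on an aromatic carbon. Among the compounds with values here, the steps that bear on it are the earlier swaps of the same five-membered ring at the same place on the shared core, which moved the read-out by a number 4 percentage points higher from compound 1 to compound 2 (within the scatter), no change at the digits printed from compound 1 to compound 3 (within the scatter) and a number 4 percentage points lower from compound 2 to compound 3 (within the scatter), none beyond the scatter. On that basis no step beyond the scatter is expected in this assay. Compound 4 is expected to give 3%, within a range of 0% to 14%. That expectation amounts to a step of a number 3 percentage points higher from compound 3 to compound 4 (within the scatter).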

Compound 4, a percentage reported as inhibition, at one concentration (the size of the read-out at that concentration, not a potency): 1%
Compound 4: the middle estimate sits 2 percentage points above what was measured; low and high end bracket the measured number.
By their numbers in this assay, from the lowest: compounds 1, 3, 4 and 2 (each within the scatter of the next).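

In this assay, this aromatic carbon, meta to a large group, also takes a 2-methyl-1,3-thiazol-4-yl group, a five-membered aromatic ring with a methyl of its own, without a step beyond the scatter (swapped for 1,3-oxazol-5-yl, it gives a number 1 percentage points higher from compound 3 to compound 4 (within the scatter)). The same holds against the other two groups at this position, with thiophen-2-yl (a number 3 percentage points lower from compound 2 to compound 4 (within the scatter)) and with the plain methyl (a number 1 percentage points higher from compound 1 to compound 4 (within the scatter)). Nothing available explains why these numbers stay so close together.

Going by these compounds, what an amine, a carboxylic acid or a longer chain at this position would do in this assay stays open. So does whether a change elsewhere on the shared core would give a step beyond the scatter.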